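The compounds below may be only part of what the source reports. "The series", "measured", "known", "first", "only" and "open" are said of these compounds alone.

Measured in a functional assay on PC-3 cells (Homo sapiens) for inhibition, read by MTT assay, with a stated time of 72 h; a higher number here means a weaker inhibitor, a lower number a stronger inhibitor:
Compound 1 `CCC(=O)O[C@@H](/C(C)=C/[C@@H](C)c1oc(CC)c(C)c(=O)c1C)[C@H](C)[C@@H](OC(=O)CC(C)C)[C@@H](C)c1oc([C@@H](C)[C@@H](O)CC)c(C)c(=O)c1C`: 3000 nM
Compound 2 `CCc1oc([C@H](C)/C=C(\C)[C@H](O)[C@H](C)[C@@H](OC(=O)CC(C)C)[C@@H](C)c2oc([C@@H](C)[C@@H](O)CC)c(C)c(=O)c2C)c(C)c(=O)c1C`: > 100000 nM

For compound 2, > 100000 nM is a limit of the assay and not a number. Compound 3 `CCc1oc([C@H](C)/C=C(\C)[C@H](OC(C)=O)[C@H](C)[C@@H](OC(=O)CC(C)C)[C@@H](C)c2oc([C@@H](C)[C@@H](O)CC)c(C)c(=O)c2C)c(C)c(=O)c1C` differs from it by acetyl in place of hydrogen on an oxygen on a saturated carbon, with acetyl in place of hydrogen on an oxygen on a saturated carbon. Among the compounds with values here, one measured step bears on this change: an at least 33-fold higher number from compound 1 to compound 2 (1.52 log units; beyond the scatter), where hydrogen replaced propanoyl on that same oxygen. Acetyl restores an acyl group there, so a large step to a lower number is expected in this assay. The expected change is an at least 20-fold lower number from compound 2 to compound 3 (1.30 log units; beyond the scatter). Compound 3 is estimated at 5000 nM, within 1500 nM to 30000 nM.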

Compound 3, half-maximal inhibitory concentration: 3000 nM
Estimate against measurement, compound 3: 1.7-fold (0.22 log units) above, and the stated range covers the measured number.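

In this assay, acetyl on this oxygen gives an at least 33-fold lower number from compound 2 to compound 3 (1.52 log units; beyond the scatter), so the activity lost with the free hydroxy returns with a second acyl group and does not depend on propanoyl alone. Going from propanoyl to acetyl gives no change at the digits printed from compound 1 to compound 3 (within the scatter), so this assay does not separate the two esters. The reading for compound 2 is a limit of the assay and not a number, so the size of the first step is only a bound: the limit of > 100000 nM in this assay, at which 1 of the 3 values shown sits.

On these data alone, whether an ester is needed here remains open, since a methyl ether or a carbamate on this oxygen could read differently. As far as these compounds go, how far the acyl group can grow, as a longer chain or a benzoyl ester, also remains open.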